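A few compounds are considered here, and "the series" means these few. Any claim that something is new, unique, unknown or untested is made for them only; others in the source may bear on it.

Measured compounds, all in an assay on HL-60 cells for agonist activity at vitamin D3 receptor (Homo sapiens), read by microscopy, with a stated time of 96 h; on this read-out higher numbers stand for an effect only at larger amounts of compound and lower numbers for an effect already at smaller amounts:

compound 1, `C#CC(C)OC(=O)c1ccc(C(CC)(CC)c2ccc(OCC(=O)C(C)(C)C)c(C)c2)n1CC`: 210 nM
compound 2, `C#CC(C)OC(=O)c1ccc(C(CC)(CC)c2ccc(OCC(O)C(C)(C)C)c(C)c2)n1CC`: 200 nM
compound 3, `CCn1c(C(=O)OCc2ccccn2)ccc1C(CC)(CC)c1ccc(OCC(=O)C(C)(C)C)c(C)c1`: > 50000 nM, which is a limit of the assay and not a number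

Compound 2 is obtained from compound 1 through (1-hydroxy-2,2-dimethylpropyl in place of (tert-butyl)carbonyl on a saturated chain carbon bound to an oxygen on an aromatic ring). This step gave a 1.1-fold lower number from compound 1 to compound 2 (0.02 log units; within the scatter). The two cores differ through ((pyridin-2-yl)methyl in place of 1-methylprop-2-yn-1-yl on an oxygen next to a carbonyl group), and that step gave an at least 230-fold higher number from compound 1 to compound 3 (2.37 log units; beyond the scatter); the size of this step is bounded only by the limit of > 50000 nM in this assay, at which 1 of the 3 values shown sits.

Compound 4, `CCn1c(C(=O)OCc2ccccn2)ccc1C(CC)(CC)c1ccc(OCC(O)C(C)(C)C)c(C)c1`, has not yet been tested. It stands to compound 3 as compound 2 stands to compound 1: the change is 1-hydroxy-2,2-dimethylpropyl in place of (tert-butyl)carbonyl on a saturated chain carbon bound to an oxygen on an aromatic ring, and its place is the same as in the pair already measured, so it is the same change. Among the measured compounds shown here, on the core of compound 3, where the only known value is a limit, the expected step from the earlier one is a number no higher from compound 3 to compound 4 (the limit leaves the size open), because the same change gave a 1.1-fold lower number from compound 1 to compound 2 (0.02 log units; within the scatter). Compound 4 is therefore estimated at 50000 nM in this assay, with a range from 20000 nM to 150000 nM, most probably reported again as a limit.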

Compound 4, half-maximal effective concentration: > 50000 nM
Compound 4: only a limit was reported; the forecaster's own chance of this, stated with the estimate: 85%; the middle value sits exactly at the limit.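

In this assay compound 4 gives > 50000 nM as a limit of the assay and not a number, so the step from compound 3, with a limit at both ends, cannot be read. With 1-hydroxy-2,2-dimethylpropyl on the saturated chain carbon, (pyridin-2-yl)methyl in place of 1-methylprop-2-yn-1-yl gives an at least 250-fold higher number from compound 2 to compound 4 (2.39 log units; beyond the scatter) and so goes the same way on both cores, though the sizes cannot be compared: the same change on two cores in this assay, an at least 230-fold higher number (2.37 log units; beyond the scatter) from compound 1 to compound 3 and an at least 250-fold higher number (2.39 log units; beyond the scatter) from compound 2 to compound 4; the limit leaves it open whether they differ. The change to 1-hydroxy-2,2-dimethylpropyl gave a 1.1-fold lower number from compound 1 to compound 2 (0.02 log units; within the scatter) but whether that carries over to the core of compound 3 is not shown, and the values on that core say nothing on it: the limit of > 50000 nM in this assay, at which 2 of the 4 values shown sit.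

Open, as far as these compounds go, is how far the group on the oxygen next to the carbonyl group can move from 1-methylprop-2-yn-1-yl before the read-out reaches the limit, since only (pyridin-2-yl)methyl stands beside it here. An ethyl or benzyl group on that oxygen, or a carboxylic acid in place of the ester, could give readable values on both cores.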